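Adding a Hydroxy Group to Compound 3: What to Expect

The source may report more compounds than this note shows. Statements on the series, on what has been measured and on what is new or still open speak of the compounds shown alone.

Of the compounds shown here, three have been measured in a functional assay on B16-BL6 cells (Mus musculus) for cytotoxicity, read by MTT assay, with a stated time of 72 h; on this read-out higher numbers stand for weaker inhibition and lower numbers for stronger inhibition. Compound 1 `COc1cc2c(cc1O)O[C@H](c1ccccc1)[C@@H](O)C2=O` reached only the limit of the assay, giving > 100000 nM. Compound 2 `COc1c(O)cc2c(c1O)C(=O)[C@H](O)[C@@H](c1ccccc1)O2` likewise stopped at the limit, with > 100000 nM. Because both sit at the limit of > 100000 nM in this assay, at which 2 of the 3 values shown sit, the step that the two limits leave unreadable from compound 1 to compound 2 cannot be read; the change there is hydroxy in place of hydrogen on an aromatic carbon. Compound 3 `COc1ccc(-c2coc3cc(O)ccc3c2=O)c(O)c1` is built on another core, and the difference between the two cores is not broken down here. In this assay, among the compounds with values here, compound 3 gives 34100 nM, the only number so far.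

Compound 4 `COc1ccc(-c2coc3cc(O)cc(O)c3c2=O)c(O)c1` has not yet been measured. It arises from compound 3 by hydroxy in place of hydrogen on an aromatic carbon. Within the data shown here, this is the same kind of change as the one from compound 1 to compound 2, though not the same: in the earlier pair the new group also sits ortho to a methoxy group, whereas here it does not. Since the earlier instance gave no readable step, the expectation rests on compound 3 alone and its 34100 nM. The expected step is a 1.1-fold lower number from compound 3 to compound 4 (0.06 log units; within the scatter), essentially no change. Compound 4 is therefore estimated at 30000 nM, most likely between 8000 nM and 100000 nM.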

Compound 4, half-maximal inhibitory concentration: > 100000 nM
Compound 4: a limit, no number; the forecaster's own chance of this, stated with the estimate: 30%; at least 3.3-fold (0.52 log units) between middle value and limit.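

On the core of compound 3, hydroxy in place of hydrogen on an aromatic carbon gives an at least 2.9-fold higher number from compound 3 to compound 4 (0.46 log units; beyond the scatter) in this assay, so this one change weakens inhibition on this core. The same kind of change on the core of compound 1 cannot be read, because compound 1 and compound 2 both stop at a limit: the limit of > 100000 nM in this assay, at which 3 of the 4 values shown sit. This leaves a single readable instance of the change, so the data show neither that its effect carries from one core to the other nor that it fails to carry.

The compounds shown leave open how far compound 4 lies past its limit, and whether any change on the core of compound 1 would bring a value down to a readable number. They also leave open what an amine or a carboxylic acid would do on the same aromatic carbon of the core of compound 3, in place of the hydroxy group.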